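The compounds below may be only part of what the source reports. "The series", "measured", "known", "first", "only" and "open" are said of these compounds alone.

Measured in a functional assay on THP-1 cells (Homo sapiens) for activation; a higher number here means that more compound is needed for the effect, a lower number that less compound is needed:
compound 1 `N#CCCc1ccc(-c2cc3ccccc3n2C(=O)c2ccccc2)cc1`: 51 nM
compound 2 `CC(C)(C)OC(=O)n1c(-c2ccc(CCC#N)cc2)cc2ccccc21`: 2470 nM
compound 3 `CC(C)(C)OC(=O)n1c(-c2ccc(CCC(=O)O)cc2)cc2ccccc21`: 7000 nM

Compound 3, at 7000 nM, has the highest of the three numbers. Compound 4 `CC(C)(C)OC(=O)n1c(-c2ccc(CCC(N)=O)cc2)cc2ccccc21` differs from it as follows: amino in place of hydroxy on a carbonyl carbon, or carboxy to carbamoyl. The closest evidence is the modest change at the same chain end, a 2.8-fold higher number from compound 2 to compound 3 (0.45 log units; beyond the scatter). The large 48-fold higher number from compound 1 to compound 2 (1.69 log units; beyond the scatter) lies elsewhere and bears little on this change. With compound 2 at 2470 nM as reference, a small move to a lower number in this assay is expected, perhaps none beyond the scatter. The expected step is a 1.8-fold lower number from compound 3 to compound 4 (0.24 log units; within the scatter). For compound 4 the estimated value is 4000 nM, with an expected range of 1300 nM to 12000 nM.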

Compound 4, half-maximal effective concentration: 2400 nM
Compound 4: middle estimate off by 1.7-fold (0.22 log units), on the high side, within the range that was stated.
By their numbers in this assay, from the lowest: compound 1; then compounds 4 and 2 (each within the scatter of the next); then compound 3.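

In this assay, amino in place of hydroxy on a carbonyl carbon gives a 2.9-fold lower number from compound 3 to compound 4 (0.46 log units; beyond the scatter) at this chain end, a change beyond the scatter. Carbamoyl in place of cyano at the same place gives a 1.0-fold lower number from compound 2 to compound 4 (0.01 log units; within the scatter) and stays within the scatter, so among these chain ends only the carboxy of compound 3 stands apart. No measurement at hand gives a reason for this.

As far as these compounds go, how an amine or a longer chain at this position would read remains open. Also open, from the compounds shown here alone, is whether 2-carbamoylethyl keeps this standing with the phenyl carbonyl of compound 1 in place of the tert-butoxy carbonyl.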